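Allyl for 4-methylbenzyl on the triazole of compound 1

This account rests on a few compounds, and the source may have more. Where it says the series, first, only, none or still open, it means among the compounds named here.

For the measured compounds named here, compound 1, `COc1ccc([C@@H]2CC(=O)c3c(O)cc(OCc4cn(Cc5ccc(C)cc5)nn4)cc3O2)cc1O`, stands highest of the three numbers so far: in a functional assay on RAW264.7 cells (Mus musculus) for inhibition, read by Griess assay, with stated times of 2 h and 24 h (a lower number here means a stronger inhibitor, a higher number a weaker inhibitor), compound 1 gives 16800 nM. Compound 2, `COc1ccc([C@@H]2C/C(=N\O)c3c(O)cc(OCc4cn(Cc5ccccc5Cl)nn4)cc3O2)cc1O`, gives 13400 nM, within the scatter of compound 1. Going by the values given here, compound 3, `COc1ccc([C@@H]2C/C(=N\O)c3c(O)cc(OCc4cn(Cc5ccccc5F)nn4)cc3O2)cc1O`, gives 5710 nM, the only measured step being a 2.3-fold lower number from compound 2 to compound 3 (0.37 log units; beyond the scatter). Compound 4, `C=CCn1cc(COc2cc(O)c3c(c2)O[C@H](c2ccc(OC)c(O)c2)CC3=O)nn1`, differs from compound 1 by vinyl in place of 4-methylphenyl on a saturated chain carbon bound to an aromatic nitrogen. Among the compounds with values here, no measured step bears on this change; the one step recorded concerns a halogen swap on the aromatic ring that is removed here, so it offers no guide. The number for compound 4 is therefore expected close to that of compound 1, with a 1.1-fold lower number from compound 1 to compound 4 (0.05 log units; within the scatter) not beyond the scatter. Compound 4 is estimated at 15000 nM, within 5000 nM to 45000 nM.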

Compound 4, half-maximal inhibitory concentration: 13800 nM
For compound 4 the middle estimate is 1.1-fold (0.04 log units) above the measured one, and the stated range covers the measured number.
By their numbers in this assay, from the lowest: compound 3; then compounds 2, 4 and 1 (each within the scatter of the next).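

In this assay, the change from 4-methylbenzyl to allyl gives a 1.2-fold lower number from compound 1 to compound 4 (0.09 log units; within the scatter). The aromatic ring of 4-methylbenzyl can therefore leave this position, on the core of compound 1, without a change in the number beyond the scatter, whereas the earlier step only compared two halogens on such a ring. No evidence available here explains this tolerance.

As far as these compounds go, whether a carboxylic acid or an amine at the end of a longer chain would fit this position remains open. So does whether allyl is tolerated equally in the oxime series of compound 2 and compound 3.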